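Working notes: compound 4, the ethyl analogue of compound 3

A few compounds are considered here, and "the series" means these few. Any claim that something is new, unique, unknown or untested is made for them only; others in the source may bear on it.

Compound 1 `Cc1ccccc1OS(=O)(=O)c1cccc(NC(=O)NCCCCl)c1` gives 21000 nM in a functional assay on HT-29 cells (Homo sapiens) for cytotoxicity, read by sulforhodamine B assay, with a stated time of 48 h; a lower number here means a stronger inhibitor, a higher number a weaker inhibitor.
Compound 2 `CCc1ccccc1OS(=O)(=O)c1cccc(NC(=O)NCCCCl)c1` gives 23000 nM in this assay.
Compound 3 `CCNC(=O)Nc1cccc(S(=O)(=O)Oc2ccccc2C)c1` gives 44000 nM in this assay.

For the measured compounds named here, compound 3 sits at the high end of the three numbers, but its gap to compound 2 is within the scatter; only the step of a 2.1-fold higher number from compound 1 to compound 3 (0.32 log units; beyond the scatter) lies beyond it. Compound 4 `CCNC(=O)Nc1cccc(S(=O)(=O)Oc2ccccc2CC)c1` differs from compound 3 by methyl in place of hydrogen on a saturated chain carbon bound to an aromatic carbon. The same change has been seen once in this assay, as a 1.1-fold higher number from compound 1 to compound 2 (0.04 log units; within the scatter), a step within the scatter. On that single precedent, the step of a 1.0-fold higher number from compound 3 to compound 4 (0.02 log units; within the scatter) is expected to stay within the scatter, with no direction worth claiming. Compound 4 is therefore estimated at 46000 nM in this assay, within a range from 23000 nM to 92000 nM.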

Compound 4, half-maximal inhibitory concentration: 33000 nM
Compound 4: middle estimate off by 1.4-fold (0.14 log units), on the high side; the measured number falls inside the stated range.
By their numbers in this assay, from the lowest: compounds 1, 2, 4 and 3 (each within the scatter of the next, the first and the last beyond it).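

The methyl in place of hydrogen on a saturated chain carbon bound to an aromatic carbon now has a second reading (a 1.3-fold lower number from compound 3 to compound 4 (0.12 log units; within the scatter)), and the two cores agree: the same change on two cores in this assay, a 1.1-fold higher number (0.04 log units; within the scatter) from compound 1 to compound 2 and a 1.3-fold lower number (0.12 log units; within the scatter) from compound 3 to compound 4, 1.5-fold (0.16 log units) apart, within the scatter of two such steps.
Hydrogen in place of chloromethyl also has a second reading (a 1.4-fold higher number from compound 2 to compound 4 (0.16 log units; within the scatter)), which stays within the scatter where the first did not, yet the two readings still agree: the same change on two cores in this assay, a 2.1-fold higher number (0.32 log units; beyond the scatter) from compound 1 to compound 3 and a 1.4-fold higher number (0.16 log units; within the scatter) from compound 2 to compound 4, 1.5-fold (0.16 log units) apart, within the scatter of two such steps.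
The change from 2-methylphenyl to 2-ethylphenyl therefore stays within the scatter on both cores.

Still open, on these data alone, is how a longer chain than ethyl, or an amine or hydroxyl on that chain carbon, would read.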